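The compounds below may be only part of what the source reports. "The series", "measured", "known", "first", "only" and "open" are said of these compounds alone.

Compound 1, `COCCOC(=O)C(O)Cn1cnc2c(N)ncnc21`, was tested in a functional assay on PRK cells (Oryctolagus cuniculus) for cytotoxicity (a lower number here means that less compound is tolerated, a higher number that more compound is tolerated), and gives > 400 ug/mL, which is a limit of the assay rather than a number. Compound 2, `Nc1ncnc2c1ncn2CC(O)C(=O)OCCO`, gives > 400 ug/mL in this assay, again a limit. Compound 3, `COC(=O)C(O)Cn1cnc2c(N)ncnc21`, likewise shows only > 400 ug/mL, a limit. For the measured compounds named here, the steps between them, a step that the two limits leave unreadable from compound 1 to compound 2, a step that the two limits leave unreadable from compound 1 to compound 3 and a step that the two limits leave unreadable from compound 2 to compound 3, therefore cannot be read, and the only evidence is that (the limit of > 400 ug/mL in this assay, at which 3 of the 3 values shown sit). Compound 4, `CC(C)OC(=O)C(O)Cn1cnc2c(N)ncnc21`, differs from compound 1 by isopropyl in place of 2-methoxyethyl on an oxygen next to a carbonyl group. Going by the values given here, none of the measured steps bears on this change with a readable size, so no change beyond the scatter is expected. Compound 4 is expected to give 400 ug/mL, within 200 ug/mL to 800 ug/mL. The expected step is a number no higher from compound 1 to compound 4 (the limit leaves the size open).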

Compound 4, minimum cytotoxic concentration: > 400 ug/mL
Compound 4: only a limit was reported; the forecaster's own chance of this, stated with the estimate: 85%; the middle value sits exactly at the limit.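

In this assay compound 4 gives > 400 ug/mL, a limit, so its steps from compound 1, compound 2 and compound 3 cannot be read. The compounds shown leave open at what concentration any of them becomes cytotoxic: the limit of > 400 ug/mL in this assay, at which 4 of the 4 values shown sit.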